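The source may report more compounds than this note shows. Statements on the series, on what has been measured and on what is new or still open speak of the compounds shown alone.

Compound 1 `Cc1ncnc2c1c(-c1cccs1)cn2[C@@H]1O[C@H](CO)[C@@H](O)[C@H]1O` — in a functional assay on HeLa S3 cells (Homo sapiens) for antiproliferative activity, read by XTT assay, with a stated time of 72 h (a lower number here means a stronger inhibitor, a higher number a weaker inhibitor), compound 1 gives > 15000 nM, a limit of the assay.
Compound 2 `Cc1ncnc2c1c(-c1ccoc1)cn2[C@@H]1O[C@H](CO)[C@@H](O)[C@H]1O` — in this assay compound 2 gives > 20000 nM, a limit of the assay.
Compound 3 `Cc1ncnc2c1c(-c1ccsc1)cn2[C@@H]1O[C@H](CO)[C@@H](O)[C@H]1O` — in this assay compound 3 gives 14300 nM.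

Compound 1 thus stands only as a limit, and one further value shown is also a limit of > 15000 nM in this assay, at which 1 of the 3 values shown sits (the limit of > 20000 nM in this assay, at which 1 of the 3 values shown sits). The step from compound 1 to compound 2 a step that the two limits leave unreadable from compound 1 to compound 2 cannot be read, while an at least 1.0-fold lower number from compound 1 to compound 3 (0.02 log units; that floor lies within the scatter) and an at least 1.3-fold lower number from compound 2 to compound 3 (0.14 log units; that floor lies within the scatter) stay within the scatter. Going by the values given here, compound 4 `CN(C)c1ncnc2c1c(-c1cccs1)cn2[C@@H]1O[C@H](CO)[C@@H](O)[C@H]1O` differs from compound 1 by dimethylamino in place of methyl on an aromatic carbon, a change at a place none of the measured steps touches, so no measured step bears on it. Compound 4 is therefore expected to stay near compound 1 in this assay, with an estimated a number no higher from compound 1 to compound 4 (the limit leaves the size open) not beyond the scatter. The estimate for compound 4 is 15000 nM, within 4000 nM to 50000 nM.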

Compound 4, half-maximal inhibitory concentration: > 20000 nM
Compound 4: a limit, no number; the forecaster's own chance of this, stated with the estimate: 60%; middle value at least 1.3-fold (0.12 log units) from the limit.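

In this assay compound 4 gives > 20000 nM, a limit of the assay. Compound 1 also stands only as a limit, so the step between compound 1 and compound 4 cannot be read. The compounds shown leave open whether dimethylamino in place of methyl changes the antiproliferative activity at all.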